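This account rests on a few compounds, and the source may have more. Where it says the series, first, only, none or still open, it means among the compounds named here.

Measured compounds:
Compound 1, `Nc1ccccc1NC(=O)c1ccc(CSC(=S)N2CCN(c3ccccc3)CC2)cc1`, gives 88.6% in a functional assay on A-375 cells (Homo sapiens) for antiproliferative activity, read by CCK-8 assay, with a stated time of 72 h, tested at 8 uM; a lower number here means a weaker effect, a higher number a stronger effect of the compound at the concentration tested.
Compound 2, `Nc1ccccc1NC(=O)c1ccc(CSC(=S)N2CCCc3ccccc32)cc1`, gives 81.5%.
Compound 3, `Cc1ccc(N2CCN(C(=S)SCc3ccc(C(=O)Nc4ccccc4N)cc3)CC2)cc1`, gives 26.4%.

Compound 2 stands second highest of the three numbers in this assay; compound 1 lies closest to it, within the usual scatter, while compound 3 lies far lower, beyond the scatter.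

Compound 4, `CN(Cc1ccncc1)C(=S)SCc1ccc(C(=O)Nc2ccccc2N)cc1`, has not yet been measured. It differs from compound 2 in one place: methyl((pyridin-4-yl)methyl)amino in place of 1,2,3,4-tetrahydroquinolin-1-yl on a thiocarbonyl carbon. Among the measured compounds shown here, the only measured step, a number 62.2 percentage points lower from compound 1 to compound 3 (beyond the scatter), concerns a different change, a methyl in place of hydrogen on an aromatic carbon, and does not bear directly on this exchange of the amine on the thiocarbonyl carbon. What the three measured compounds do show is that changing the group on that carbon can move the number widely, from the level of compound 1 down to that of compound 3. The step from compound 2 to compound 4 is therefore expected to be a number 21.5 percentage points lower from compound 2 to compound 4 (beyond the scatter), with a downward lean and considerable uncertainty.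

Compound 4 is estimated at 60%, in a range from 30% to 88%.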

Compound 4, a percentage reported as inhibition, at one concentration (the size of the read-out at that concentration, not a potency): 86.1%
Beside the measured number, compound 4's estimate is 26.1 percentage points below it; the range from low to high includes it.
By their numbers in this assay, from the lowest: compound 3; then compounds 2, 4 and 1 (each within the scatter of the next).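

At the thiocarbonyl carbon, methyl((pyridin-4-yl)methyl)amino in place of 1,2,3,4-tetrahydroquinolin-1-yl gives a number 4.6 percentage points higher from compound 2 to compound 4 (within the scatter) in this assay. This position therefore accepts a group with one six-membered ring instead of two, and with a hydrogen-bond acceptor where there was none, without a change in the read-out beyond the scatter. Among the compounds shown here, the earlier compounds did not show this, as the only step among them concerned a methyl on an aromatic carbon.

As far as these compounds go, a morpholine or a plain dimethylamino group on the thiocarbonyl carbon remains open. So does a benzyl in place of the (pyridin-4-yl)methyl part, which would show whether the ring nitrogen of compound 4 matters. Nothing given here explains why the read-out holds across this exchange.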